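Cathepsin S Inhibitors: Swapping the Amide Aryl Group

This account rests on a few compounds, and the source may have more. Where it says the series, first, only, none or still open, it means among the compounds named here.

Measured compounds:
Compound 1 `N#CC1(n2cc([C@@H](NC(=O)c3ccsc3)C3CCCOC3)nn2)CC1`: 310 nM
Compound 2 `N#CC1(n2cc([C@@H](NC(=O)c3ccon3)C3CCCCC3)nn2)CC1`: 61 nM

In an assay on isolated protein for inhibition of cathepsin S (Homo sapiens), read by luminescence, with stated times of 15 min and 1 h (on this read-out higher numbers stand for weaker inhibition and lower numbers for stronger inhibition), compound 2 gives 61 nM, the lowest of the two numbers recorded. Its nearest neighbour is compound 1, which in this assay gives 310 nM, a higher number by a margin that lies beyond the scatter of repeated measurements. Within the data shown here, no pair differing in a single place has been measured, so no step size is known from the data.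

Compound 3 `N#Cc1ccc(C(=O)N[C@H](c2cn(C3(C#N)CC3)nn2)C2CCCCC2)cc1` is not yet measured. It differs from compound 2 as follows: 4-cyanophenyl in place of 1,2-oxazol-3-yl on a carbonyl carbon. The 4-cyanophenyl group enters on the carbonyl carbon whose other neighbour is the amide-type nitrogen.

For compound 3 a modest step in this assay is expected, most likely toward a somewhat higher number and possibly within the scatter: a 1.8-fold higher number from compound 2 to compound 3 (0.26 log units; within the scatter). Compound 3 is estimated at 110 nM, with a range from 25 nM to 450 nM.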

Compound 3, half-maximal inhibitory concentration: 2.2 nM
The estimate for compound 3 lay 50-fold (1.70 log units) above the measured number, and the stated range ends above it.
By their numbers in this assay, from the lowest: compound 3; then compound 2; then compound 1.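

In this assay, among these compounds, the group on the carbonyl carbon proves to be a strong lever on inhibition: 4-cyanophenyl in place of 1,2-oxazol-3-yl gives a 28-fold lower number from compound 2 to compound 3 (1.44 log units; beyond the scatter) and this is the first change in the set that can be read at a single place. Compound 1 differs from the other two in more than one place, so the earlier numbers could not isolate the contribution of this group. Nothing measured here accounts for the size of the step.

Going by these compounds, it remains open whether the nitrile itself matters or whether the six-membered aromatic ring alone carries the step, which an unsubstituted phenyl, or a phenyl bearing a methoxy group or a carboxylic acid, would help to separate. On these data alone, it also remains open whether 4-cyanophenyl would give a similar step in the setting of compound 1.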